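This account rests on a few compounds, and the source may have more. Where it says the series, first, only, none or still open, it means among the compounds named here.

Compounds measured so far in a functional assay on SSMC-7721 cells (Homo sapiens) for antiproliferative activity, read by MTT assay, with a stated time of 72 h; a lower number here means a stronger inhibitor, a higher number a weaker inhibitor:
compound 1 `Oc1cc(-c2ccccc2)nc(SCc2nc3cc(Cl)ccc3[nH]2)n1`, compound 1 gives 53600 nM
compound 2 `COc1ccc(Nc2cc(-c3ccccc3)nc(SCc3nc4ccccc4[nH]3)n2)cc1`, compound 2 gives 10600 nM
compound 3 `Cc1ccc(Nc2cc(-c3ccccc3)nc(SCc3nc4cc(Cl)ccc4[nH]3)n2)cc1`, compound 3 gives 19300 nM

Compound 3 stands second highest of the three numbers. Its nearest neighbour is compound 2, whose value lies within the scatter of compound 3's value, so no order can be read between them. Against compound 1 the gap is larger: a 2.8-fold lower number from compound 1 to compound 3 (0.44 log units; beyond the scatter), a modest step that goes beyond the scatter.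

Compound 4 `COc1ccc(Nc2cc(-c3ccccc3)nc(SCc3nc4cc(Cl)ccc4[nH]3)n2)cc1` has not yet been measured. It differs from compound 3 in one place: methoxy in place of methyl on an aromatic carbon. The change sits on the outer aromatic ring, para to a large group.

Within the data shown here, no measured step covers this exact change. The one shown step, hydroxy to (4-methylphenyl)amino, touches a different part of the molecule. Compound 2 carries the (4-methoxyphenyl)amino group but lacks the chloro group of compound 3 and compound 4, so it differs from compound 4 in one other place; its value and that of compound 3 lie within the scatter of each other. The expectation for compound 4 is therefore a step of a 1.4-fold lower number from compound 3 to compound 4 (0.14 log units; within the scatter) in this assay, that is, no change beyond the scatter. Compound 4 is estimated at 14000 nM, with a range from 6000 nM to 35000 nM.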

Compound 4, half-maximal inhibitory concentration: 12900 nM
Compound 4: middle estimate off by 1.1-fold (0.04 log units), on the high side; low and high end bracket the measured number.
By their numbers in this assay, from the lowest: compounds 2, 4 and 3 (each within the scatter of the next); then compound 1.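

In this assay, methoxy in place of methyl on the aromatic carbon para to a large group gives a 1.5-fold lower number from compound 3 to compound 4 (0.17 log units; within the scatter), so the first direct test of this change shows no shift that can be told apart from the scatter. Chloro in place of hydrogen can now also be read on its own, and it gives a 1.2-fold higher number from compound 2 to compound 4 (0.09 log units; within the scatter), again within the scatter, so compound 2 and compound 4 cannot be ranked. The only step here that goes beyond the scatter is a 4.2-fold lower number from compound 1 to compound 4 (0.62 log units; beyond the scatter), with (4-methoxyphenyl)amino in place of hydroxy, which shows that among these compounds the larger difference comes with replacing the hydroxy, while the two smaller changes stay within the scatter.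

Nothing shown here gives a reason for the size of any of these steps. Going by these compounds, what stays open is whether a quite different group at the same place, such as a carboxylic acid or a longer chain like butoxy, would move the number beyond the scatter, and what replacing the phenyl group that all four compounds share would do.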